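This account rests on a few compounds, and the source may have more. Where it says the series, first, only, none or still open, it means among the compounds named here.

Compound 1 `COc1ccc(S(=O)(=O)Nc2ccc(-c3nc4ccccc4o3)cc2)cc1`: in an assay on cells for inhibition of HSP60/HSP10 (Homo sapiens), with a stated time of 60 min (a lower number here means a stronger inhibitor, a higher number a weaker inhibitor), compound 1 gives > 100000 nM, which is a limit of the assay rather than a number.
Compound 2 `O=S(=O)(Nc1ccc2oc(-c3ccccc3)nc2c1)c1ccccc1C(F)(F)F`: in this assay compound 2 gives > 100000 nM, again a limit.
Compound 3 `O=S(=O)(Nc1ccc2oc(-c3ccccc3)nc2c1)c1ccccc1Cl`: in this assay compound 3 gives > 100000 nM, also a limit.

Compound 3 thus stands at the limit, together with the two other measured compounds, as summed up by the limit of > 100000 nM in this assay, at which 3 of the 3 values shown sit. Within the data shown here, the only step between measured compounds that differ in one place, a step that the two limits leave unreadable from compound 2 to compound 3, cannot be read in size, since both ends are limits.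

Compound 4 `CCc1ccc(S(=O)(=O)Nc2ccc3oc(-c4ccccc4)nc3c2)cc1` has not yet been measured in this assay. It differs from compound 3 by 4-ethylphenyl in place of 2-chlorophenyl on a sulfonyl sulfur. Among the measured compounds shown here, no measured step bears on this change in a readable way. For the measured compounds named here, since every compound measured so far sits at the limit recorded in the limit of > 100000 nM in this assay, at which 3 of the 3 values shown sit, compound 4 is expected to sit there too, with the estimated step of a number no higher from compound 3 to compound 4 (the limit leaves the size open) not read beyond the scatter. The estimate for compound 4 in this assay is 100000 nM, within a range from 30000 nM to 300000 nM, most likely reported as a limit only.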

Compound 4, half-maximal inhibitory concentration: > 100000 nM
Compound 4: only a limit was reported; the forecaster's own chance of this, stated with the estimate: 85%; the middle value lies on the limit itself.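

Among these compounds, no step from compound 3 to compound 4 can be read, since both ends are limits of the assay: the limit of > 100000 nM in this assay, at which 4 of the 4 values shown sit.
The compounds shown leave open whether any change to the group on the sulfonyl sulfur or to the shared core would bring a value inside the range of this assay at all.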